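This account rests on a few compounds, and the source may have more. Where it says the series, first, only, none or still open, it means among the compounds named here.

Compound 1 `Cn1nc(Cc2nnc(SCCCCCCCC(=O)Nc3ccc(Cl)cc3Cl)n2CCC=O)c2ccccc2c1=O` is measured in an assay on NK92 cells for inhibition of interleukin-15 (Homo sapiens), read by AlphaScreen, with stated times of 30 min and 1 h (on this read-out higher numbers stand for weaker inhibition and lower numbers for stronger inhibition), where compound 1 gives 710 nM. Compound 2 `Cn1nc(Cc2nnc(SCCCCCCCC(=O)Nc3ccc(Cl)cc3Cl)n2CCCO)c2ccccc2c1=O` carries one change relative to compound 1, (hydroxymethyl in place of formyl on a saturated chain carbon, two bonds along the chain from an aromatic nitrogen). For compound 2 the assay reports only a limit, > 30000 nM, as described by the limit of > 30000 nM in this assay, at which 1 of the 3 values shown sits. The step is an at least 42-fold higher number from compound 1 to compound 2 (1.62 log units; beyond the scatter). Compound 3 `Cn1c(Cc2nn(CCC=O)c(=O)c3ccccc23)nnc1SCC(=O)Nc1ccc(Cl)cc1Cl` has a different core; the difference between the two cores is not broken down here. In this assay compound 3 gives 20000 nM, the highest of the two numbers recorded. Compound 4 `Cn1c(Cc2nn(CCCO)c(=O)c3ccccc23)nnc1SCC(=O)Nc1ccc(Cl)cc1Cl` has not yet been measured; it differs from compound 3 by hydroxymethyl in place of formyl on a saturated chain carbon, two bonds along the chain from an aromatic nitrogen, and the place of the change is the same as in the pair from compound 1 to compound 2. On the strength of that earlier step, the change from compound 3 to compound 4 is expected to be of similar direction, a 4.0-fold higher number from compound 3 to compound 4 (0.60 log units; beyond the scatter), and compound 4 is estimated at 80000 nM, between 20000 nM and 300000 nM, most likely reported as a limit because the limit of > 30000 nM in this assay, at which 1 of the 3 values shown sits, sits close to the value of compound 3.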

Compound 4, half-maximal inhibitory concentration: 30000 nM
Compound 4: middle estimate off by 2.7-fold (0.43 log units), on the high side; the measured number falls inside the stated range.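

Putting hydroxymethyl in place of formyl, on a saturated chain carbon two bonds along the chain from an aromatic nitrogen, gives a 1.5-fold higher number from compound 3 to compound 4 (0.18 log units; within the scatter), and this does not match the step seen for the same change on the other core: the same change on two cores in this assay, an at least 42-fold higher number (1.62 log units; beyond the scatter) from compound 1 to compound 2 and a 1.5-fold higher number (0.18 log units; within the scatter) from compound 3 to compound 4, at least 28-fold (1.44 log units) apart, beyond the scatter of two such steps

The value of compound 2, > 30000 nM, is a limit and not an exact number.

For the compounds shown here, the result shows that the large step seen on the core of compound 1 cannot be assumed to carry over to the core of compound 3, but with only one pair on each core, it does not explain the difference or predict the outcome on any further core.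

The compounds shown leave open how a carboxylic acid or an amine at the end of this chain would fare on either core. Also open, from the compounds shown here alone, is which part of the difference between the two cores decides the size of the step.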